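Bromo for Chloro on the Benzyl Ring of Compound 2

A few compounds are considered here, and "the series" means these few. Any claim that something is new, unique, unknown or untested is made for them only; others in the source may bear on it.

Two triazole ethers have been tested in an ADME assay on PANC-1 cells (Homo sapiens) for inhibition, read by MTT assay, with a stated time of 48 h; a lower number here means a stronger inhibitor of growth, a higher number a weaker inhibitor of growth. Compound 1 `O=[N+]([O-])c1ccc(Cn2cc(COc3ccc(Cl)cc3)nn2)cc1` reached only the limit of the assay, giving > 100 ug/mL. Compound 2 `Clc1ccc(Cn2cc(COc3c(Cl)cc(Cl)cc3Cl)nn2)cc1` also stopped at the limit, giving > 100 ug/mL. On the numbers shown, compound 2 therefore stands at the assay limit and nowhere else, with no numerical value to place it against, and both values sit at the same point, (the limit of > 100 ug/mL in this assay, at which 2 of the 2 values shown sit). Compound 3 `Clc1cc(Cl)c(OCc2cn(Cc3ccc(Br)cc3)nn2)c(Cl)c1` has not yet been measured; it differs from compound 2 by bromo in place of chloro on an aromatic carbon. For the measured compounds named here, no step between measured compounds is available, so the expectation rests on compound 2 alone. The expected step that the limit leaves unreadable from compound 2 to compound 3 is none beyond the scatter, since compound 2 gave > 100 ug/mL. Compound 3 is therefore expected to give about 110 ug/mL, ranging from 50 ug/mL to 250 ug/mL.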

Compound 3, concentration for 50% growth inhibition: > 100 ug/mL
Compound 3 gave a limit, no number; the forecaster's own chance of this, stated with the estimate: 80%; the middle value does not contradict the limit.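

Compound 2 and compound 3 both gave only a limit, not a number, so no step can be read for bromo in place of chloro: the limit of > 100 ug/mL in this assay, at which 3 of the 3 values shown sit. The compounds shown leave open whether this exchange alters growth inhibition at all, and which structures would give a readable value.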